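The compounds below may be only part of what the source reports. "The series", "measured", "known", "first", "only" and "open" are said of these compounds alone.

In a functional assay on cells (Melanoma cell, Homo sapiens) for inhibition (on this read-out higher numbers stand for weaker inhibition of growth and lower numbers for stronger inhibition of growth), compound 2 (`N=C(N)N/N=C/c1c(-c2cc(Cl)sc2Cl)nc2n1CCS2`) gives 10000 nM and lies within the scatter of both compound 1 (`Cc1cc(-c2nc3sc(C)cn3c2/C=N/NC(=N)N)c(C)s1`) and compound 3 (`Cc1cc(-c2nc3sccn3c2/C=N/NC(=N)N)c(C)s1`). The change to compound 4 (`Cc1cc(-c2nc3n(c2/C=N/NC(=N)N)CCS3)c(C)s1`) is 2,5-dimethylthiophen-3-yl in place of 2,5-dichlorothiophen-3-yl on an aromatic carbon and leaves the rest of compound 2 untouched: 2,5-dimethylthiophen-3-yl in place of 2,5-dichlorothiophen-3-yl on an aromatic carbon. Within the data shown here, no measured step makes this exchange. The only one available, a 2.2-fold higher number from compound 1 to compound 3 (0.34 log units; beyond the scatter) when hydrogen replaces methyl on an aromatic carbon, is modest and concerns a different change. Compound 1 (7410 nM) and compound 3 (16200 nM) already carry 2,5-dimethylthiophen-3-yl and both lie within the scatter of compound 2, so no step beyond the scatter is expected in this assay here. The expected step is a 1.2-fold higher number from compound 2 to compound 4 (0.08 log units; within the scatter) and no larger. Compound 4 is estimated at 12000 nM with a likely range of 5500 nM to 26000 nM in this expectation.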

Compound 4, concentration for 50% growth inhibition: 15500 nM
For compound 4 the middle estimate is 1.3-fold (0.11 log units) below the measured one, within the range that was stated.
By their numbers in this assay, from the lowest: compounds 1, 2, 4 and 3 (each within the scatter of the next, the first and the last beyond it).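

In this assay the direct exchange of 2,5-dichlorothiophen-3-yl for 2,5-dimethylthiophen-3-yl gives a 1.6-fold higher number from compound 2 to compound 4 (0.19 log units; within the scatter) and stays within the scatter. At this position on this core, the two groups therefore cannot be told apart in this read-out. No measurement at hand bears on why they read alike.

Going by these compounds, whether the same exchange would also read alike on the cores of compound 1 and compound 3 stays open. So does the outcome with a very different group here, such as an amine or a carboxylic acid on the thiophene.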